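The source may report more compounds than this note shows. Statements on the series, on what has been measured and on what is new or still open speak of the compounds shown alone.

Working notes on the series.

Two compounds have been taken through a functional assay on HL-60 cells (Homo sapiens) for antiproliferative activity, read by MTT assay; on this read-out higher numbers stand for weaker inhibition and lower numbers for stronger inhibition. Going by the values given here, compound 1, `C=C[C@@H]1O[C@H](COCc2ccccc2)[C@@H](OCc2ccccc2)[C@H](OCc2ccccc2)[C@H]1O`, gives 11800 nM in this assay, the only number reported in the set. Compound 2, `CCCCCCCCCCCCCCCOC[C@H]1O[C@@H](CCC)[C@H](O)[C@@H](OCCCCCCCCCCCCCCC)[C@@H]1OCCCCCCCCCCCCCCC`, gives "not active" (no number reported) in this assay, so no number stands beside it and its value cannot be put in order against compound 1.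

The next compound, compound 3, `O[C@H]1CO[C@H](COCc2ccccc2)[C@@H](OCc2ccccc2)[C@@H]1OCc1ccccc1`, is yet to be measured in this assay. It differs from compound 1 in one place: hydrogen in place of vinyl on a saturated ring carbon. The change is the loss of the vinyl, two carbon atoms and one double bond, from a saturated ring carbon of the core that compound 1 and compound 3 share; nothing else moves.

Among the compounds with values here, no pair of measured compounds differs in one place, so no measured step guides the size of this change. Within the data shown here, with the only number in the set lying at the weak end, the step from compound 1 to compound 3 is expected to be small, either within the scatter or a modest weakening, a 1.7-fold higher number from compound 1 to compound 3 (0.23 log units; within the scatter). Compound 3 is accordingly estimated at 20000 nM, within 7000 nM to 60000 nM.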

Compound 3, half-maximal inhibitory concentration: "not active" (no number reported)
For compound 3 the study gives words and no number, so the estimate cannot be set against anything.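

In this assay, going by these compounds alone, compound 3 gives "not active" (no number reported) and compound 1 gives 11800 nM so no step from compound 1 to compound 3 can be read. The compounds shown leave open whether losing the vinyl changes activity at all, and how far. No measurement shown offers any explanation of the result for compound 3.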